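The source may report more compounds than this note shows. Statements on the series, on what has been measured and on what is new or still open speak of the compounds shown alone.

Compound 1 `O=C(O)CCC(=O)N(C1CC1)[C@H]1c2ccccc2N(C(=O)c2ccc(OC(F)(F)F)cc2)[C@H]2CC[C@H]21`, in an assay on cells for displacement of a labelled ligand from prostaglandin D2 receptor 2 (Homo sapiens), read by scintillation counting, with a stated time of 60 min (on this read-out higher numbers stand for weaker inhibition and lower numbers for stronger inhibition), compound 1 gives 4 nM.
Compound 2 `O=C(O)COC(=O)N(C1CC1)[C@H]1c2ccccc2N(C(=O)c2cccc(F)c2)[C@H]2CC[C@H]21`, in this assay compound 2 gives 4.1 nM.
Compound 3 `O=C(O)CCC(=O)N(C1CC1)[C@H]1c2ccccc2N(C(=O)c2ccc(F)cc2)[C@H]2CC[C@H]21`, in this assay compound 3 gives 7.3 nM.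

Compound 3 sits within the scatter of both other numbers: its difference from compound 1 is a 1.8-fold higher number from compound 1 to compound 3 (0.26 log units; within the scatter), and its value and that of compound 2 are likewise within the scatter of each other. Compound 4 `O=C(O)COC(=O)N(C1CC1)[C@H]1c2ccccc2N(C(=O)c2ccc(F)cc2)[C@H]2CC[C@H]21` differs from compound 3 by carboxymethoxy in place of 2-carboxyethyl on a carbonyl carbon. Going by the values given here, no measured step covers this change on its own; compound 2 carries the carboxymethoxy group but with a different fluorine placement, so its value only shows that such a compound can reach the same range. Compound 4 is therefore expected to stay close to compound 3, with a step of a 1.5-fold lower number from compound 3 to compound 4 (0.16 log units; within the scatter) in this assay, not beyond the scatter. The estimate for compound 4 is 5 nM, ranging from 2 nM to 13 nM.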

Compound 4, inhibition constant: 3.5 nM
Beside the measured number, compound 4's estimate is 1.4-fold (0.15 log units) above it, within the range that was stated.
By their numbers in this assay, from the lowest: compounds 4, 1, 2 and 3 (each within the scatter of the next, the first and the last beyond it).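

Going by these compounds alone, on the carbonyl carbon whose other neighbour is the amide-type nitrogen, carboxymethoxy in place of 2-carboxyethyl gives a 2.1-fold lower number from compound 3 to compound 4 (0.32 log units; beyond the scatter) in this assay, the first reading of this change on its own. With carboxymethoxy in place, 4-fluorophenyl in place of 3-fluorophenyl gives a 1.2-fold lower number from compound 2 to compound 4 (0.07 log units; within the scatter), so the fluorine placement does not separate these two compounds. No evidence at hand explains either step.

The compounds shown leave open whether the first step holds alongside the trifluoromethoxy group of compound 1. They also leave open how a longer chain or an amine in place of the carboxylic acid would read on this carbonyl carbon.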